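The compounds below may be only part of what the source reports. "The series", "measured", "known", "first", "only" and "open" are said of these compounds alone.

In a functional assay on A549 cells (Homo sapiens) for cytotoxicity, read by MTT assay, with a stated time of 72 h (a lower number here means a stronger inhibitor, a higher number a weaker inhibitor), compound 1 `COc1ccc(OC)c(/C=C/C(=O)Nc2cc3c(Nc4ccc(F)c(Cl)c4)ncnc3cc2OC)c1` gives 11200 nM. In the same test, compound 2 `COc1ccc(OC)c(/C=C/C(=O)Nc2cc3c(Nc4ccc(F)c(Cl)c4)ncnc3cc2O[C@H]2CCOC2)c1` gives 7300 nM and compound 3 `O=C(/C=C/c1cc(Br)c(O)c(Br)c1)Nc1cc2c(Nc3ccc(F)c(Cl)c3)ncnc2cc1O[C@H]1CCOC1` gives 28800 nM. Compound 1 and compound 2 thus lie within the scatter of each other, while compound 3 carries the highest number of the three.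

Compound 4 `COc1cc2ncnc(Nc3ccc(F)c(Cl)c3)c2cc1NC(=O)/C=C/c1ccc(C#N)cc1` keeps the rest of compound 1 and exchanges one group at the end of the chain: 4-cyanophenyl in place of 2,5-dimethoxyphenyl on a double-bonded chain carbon bound to a double-bonded chain carbon. The nearest guide is a 3.9-fold higher number from compound 2 to compound 3 (0.60 log units; beyond the scatter), where the same 2,5-dimethoxyphenyl group gave way to 3,5-dibromo-4-hydroxyphenyl, a modest step beyond the scatter. The other measured step, a 1.5-fold lower number from compound 1 to compound 2 (0.19 log units; within the scatter), lies in a different place and stays within the scatter, so it offers little help here. Going by the values given here, no measured compound carries 4-cyanophenyl, and a single exchange cannot settle the direction for a different group. The expectation is therefore only a slight upward move, within the scatter, with a wide margin on both sides. The estimated change is a 1.3-fold higher number from compound 1 to compound 4 (0.10 log units; within the scatter). Compound 4 is expected at 14000 nM, with an estimated range of 5000 nM to 40000 nM.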

Compound 4, half-maximal inhibitory concentration: "not active" (no number reported)
Compound 4 has no reported number here, so the estimate cannot be set against anything.
By their numbers in this assay, from the lowest: compounds 2 and 1 (each within the scatter of the next); then compound 3.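

In this assay, going by these compounds alone, compound 4 is reported only as "not active", without a number, so no step from compound 1 to compound 4 can be read. How far compound 4 lies from compound 1 stays open, and no measurement at hand offers an explanation for the result.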